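The source may report more compounds than this note shows. Statements on the series, on what has been measured and on what is new or still open speak of the compounds shown alone.

In a functional assay on MCF7 cells (Homo sapiens) for antiproliferative activity, read by CCK-8 assay, with a stated time of 48 h (a lower number here means a stronger inhibitor, a higher number a weaker inhibitor), compound 1 `C=CC(=O)NCCOc1ccc(Oc2c(-c3ccc(F)cc3)sc3cc(O)ccc23)cc1` gives 23000 nM, and compound 3 `C/C=C/C(=O)N1CC(Oc2ccc(Oc3c(-c4ccc(F)cc4)sc4cc(O)ccc34)cc2)C1` gives 28000 nM. These two values lie within the scatter of each other, so compound 1 cannot be separated from its nearest measured neighbour. Compound 2 `C=C(C)C(=O)NCCOc1ccc(Oc2c(-c3ccc(F)cc3)sc3cc(O)ccc23)cc1` is reported only as a limit, > 25000 nM.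

Compound 4 `CN(C)C(=O)/C=C/CNCCOc1ccc(Oc2c(-c3ccc(F)cc3)sc3cc(O)ccc23)cc1` keeps the core of compound 1 but carries 3-(dimethylcarbamoyl)prop-2-en-1-yl in place of vinylcarbonyl on an amine nitrogen.

Among the measured compounds shown here, no measured step makes this exact change, but two of them alter the vinylcarbonyl part of compound 1. Putting a methyl in place of a hydrogen on the double-bonded chain carbon gave an at least 1.0-fold higher number from compound 1 to compound 2 (0.03 log units; that floor lies within the scatter). As far as these compounds go, this figure is only a floor, set by the limit of > 25000 nM in this assay, at which 1 of the 3 values shown sits, so the true size of that step remains unknown. Replacing 2-((vinylcarbonyl)amino)ethyl with 1-((prop-1-en-1-yl)carbonyl)azetidin-3-yl gave a 1.2-fold higher number from compound 1 to compound 3 (0.09 log units; within the scatter).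

With only these small or open-ended steps as a guide, no change beyond the scatter is expected in this assay, in either direction, although the new group is larger and the uncertainty is wide. The estimate amounts to a 1.3-fold lower number from compound 1 to compound 4 (0.11 log units; within the scatter), which is an expected step within that scatter. For compound 4 the expected value is 18000 nM, with an estimated range from 5000 nM to 32000 nM.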

Compound 4, half-maximal inhibitory concentration: 13800 nM
The estimate for compound 4 lay 1.3-fold (0.12 log units) above the measured number, within the range that was stated.
By their numbers in this assay, from the lowest: compounds 4, 1 and 3 (each within the scatter of the next, the first and the last beyond it).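

In this assay, the amine nitrogen of compound 1 takes the larger 3-(dimethylcarbamoyl)prop-2-en-1-yl in place of vinylcarbonyl, a group of 8 heavy atoms instead of 4, with a 1.7-fold lower number from compound 1 to compound 4 (0.22 log units; within the scatter), so enlarging this group brings no loss of activity and no clear gain. The first separation beyond the scatter in this set is a 2.0-fold lower number from compound 3 to compound 4 (0.31 log units; beyond the scatter), but that modest step replaces the whole group on the oxygen, azetidine ring included, so no single part of that group can be credited with it. A limit leaves the remaining step as a floor only, an at least 1.8-fold lower number from compound 2 to compound 4 (0.25 log units; that floor lies within the scatter): the limit of > 25000 nM in this assay, at which 1 of the 4 values shown sits.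

As far as these compounds go, whether a diethylcarbamoyl group or a carboxylic acid in place of the dimethylcarbamoyl would change the number beyond the scatter remains open. The compounds shown also cannot tell whether the step to compound 4 comes from the dimethylcarbamoyl group or from the loss of the carbonyl on the amine nitrogen, since both changes arrive together.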